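The source may hold more compounds than are shown below. What is called first, only, known or untested is meant among the compounds shown, and "the series" means these compounds.

Working notes on the thiosemicarbazide series.

Two compounds have been run in a functional assay on MCF7 cells (Homo sapiens) for cytotoxicity, read by MTT assay, with a stated time of 72 h, tested at 10 uM; on this read-out higher numbers stand for more inhibition of growth at the one concentration tested and lower numbers for less inhibition of growth. Compound 1 `Cc1cccc(/C(N)=N/NC(=S)N2CCN(c3ccccn3)CC2)n1` gives 20.8% in this assay. Compound 2 `Cc1cccc(/C(N)=N/NC(=S)N2CCSCC2)n1`, which carries a thiomorpholine in place of the pyridinyl-piperazine, gives 22.5% in this assay. The two numbers lie within the usual scatter of each other, so compound 1 and compound 2 cannot be told apart on this read-out; both sit in the weak range at the single concentration tested. Among the compounds with values here, no step between the measured compounds can be drawn for the change now considered.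

Compound 3 `Cc1ccnc(/C(N)=N/NC(=S)N2CCN(c3ccccn3)CC2)c1` is the next member to be run. It differs from compound 1 only in where the methyl sits on the pyridine ring: 4-methylpyridin-2-yl in place of 6-methylpyridin-2-yl on a carbon with a double bond to nitrogen. The rest of the molecule, including the pyridinyl-piperazine thiosemicarbazide, is unchanged.

With nothing in the measured pair bearing on this change, the step from compound 1 to compound 3 in this assay is expected to be small, in no settled direction, and not beyond the scatter: a number 1.2 percentage points higher from compound 1 to compound 3 (within the scatter). For compound 3 the expected result in this assay is therefore 22%, with a plausible range from 8% to 38%, pending the measurement.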

Compound 3, percent growth inhibition at one concentration: 32.1%
Estimate against measurement, compound 3: 10.1 percentage points below; measured number inside the range.
By their numbers in this assay, from the lowest: compounds 1, 2 and 3 (each within the scatter of the next, the first and the last beyond it).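

With 4-methylpyridin-2-yl in place of 6-methylpyridin-2-yl on a carbon with a double bond to nitrogen, the series gives in this assay a number 11.3 percentage points higher from compound 1 to compound 3 (beyond the scatter) and thus its first step beyond the scatter. The earlier pair had no change on the pyridine ring, whereas here the same atoms, joined differently, are enough to separate two compounds on this read-out, even though the step is modest and rests on a single pair at one concentration. No measurement at hand bears on why the two placements of the methyl differ.

Open, as far as these compounds go, is how a plain pyridin-2-yl, without any methyl, would stand against compound 1 and compound 3, and whether an ethyl or a methoxy group in place of the methyl of the 4-methylpyridin-2-yl would keep, extend or lose the step. Also open is whether 4-methylpyridin-2-yl brings a similar step when paired with the thiomorpholine of compound 2, since that pairing is not among the compounds shown here.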